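Carboxyalkyl amides: an expectation for compound 3

This account rests on a few compounds, and the source may have more. Where it says the series, first, only, none or still open, it means among the compounds named here.

- compound 1 `CCn1c(C(=O)NCC(=O)O)ccc1C(CC)(CC)c1ccc(OCS(=O)(=O)c2ccccc2)c(C)c1`: 30100 nM
- compound 2 `CCn1c(C(=O)N[C@@H](C(=O)O)C(C)C)ccc1C(CC)(CC)c1ccc(OCS(=O)(=O)c2ccccc2)c(C)c1`: 3070 nM

Both values come from a functional assay on PC-3 cells (Homo sapiens) for antiproliferative activity, read by MTT assay, with a stated time of 24 h (on this read-out lower numbers stand for stronger inhibition and higher numbers for weaker inhibition), where compound 2 has the lower number of the pair. Compound 3 `CCn1c(C(=O)NCCC(=O)O)ccc1C(CC)(CC)c1ccc(OCS(=O)(=O)c2ccccc2)c(C)c1` carries the change 2-carboxyethyl in place of 1-carboxy-2-methylpropyl on an amide-type nitrogen. For the measured compounds named here, the one measured step bearing on this is a 9.8-fold lower number from compound 1 to compound 2 (0.99 log units; beyond the scatter), with isopropyl in place of hydrogen on a saturated chain carbon. Compound 3 has no isopropyl, so a step of similar or somewhat smaller size towards a higher number is expected. The expected step is a 4.9-fold higher number from compound 2 to compound 3 (0.69 log units; beyond the scatter). Compound 3 is estimated at 15000 nM, with an expected range of 5000 nM to 45000 nM.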

Compound 3, half-maximal inhibitory concentration: 14400 nM
Compound 3: the middle estimate sits 1.0-fold (0.02 log units) above what was measured, and the stated range covers the measured number.
By their numbers in this assay, from the lowest: compound 2; then compound 3; then compound 1.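

In this assay the substituent on the amide-type nitrogen reads differently with each chain: 2-carboxyethyl in place of 1-carboxy-2-methylpropyl gives a weaker result (a 4.7-fold higher number from compound 2 to compound 3 (0.67 log units; beyond the scatter)). Carboxymethyl in place of carboxy on the saturated chain carbon gives a stronger one (a 2.1-fold lower number from compound 1 to compound 3 (0.32 log units; beyond the scatter)), so an unbranched chain extension also moves the number, and compound 3 falls between compound 2 and compound 1.

Still open, as far as these compounds go, is how a longer chain, or an amine in place of the carboxylic acid, would read at this position. No supporting evidence accounts for these steps.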